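The source may report more compounds than this note shows. Statements on the series, on what has been measured and on what is new or still open speak of the compounds shown alone.

Compound 1 `COc1nc(C)nc(/N=C/c2ccc(C)cc2)n1` is the reference for this step. In an ADME assay on Vero cells (Chlorocebus sabaeus) for cytotoxicity, read by MTT assay, with a stated time of 72 h (a lower number here means a stronger inhibitor, a higher number a weaker inhibitor), compound 1 gives no number but only a limit, > 50 ug/mL. Compound 2 `CCOc1cc(/C=N/c2nc(C)nc(OC)n2)ccc1O` in this assay also reaches only a limit, > 50 ug/mL. For compound 3 `COc1nc(C)nc(/N=C/c2cccc([N+](=O)[O-])c2)n1` this assay gives "not determined" (no result reported), so no figure is available for it. Compound 1 therefore stands at a limit, with one further compound at the same limit and one entry without any number; the cytotoxicity readings shared so far sit at the limit of > 50 ug/mL in this assay, at which 2 of the 3 values shown sit.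

The compound to be measured is compound 4 `C=CCOc1ccc(/C=N/c2nc(C)nc(OC)n2)cc1`. It differs from compound 1 by allyloxy in place of methyl on an aromatic carbon. Among the compounds with values here, no step between measured compounds exists that would show how this assay responds to a change of this kind. The expectation for the step from compound 1 to compound 4 is therefore no shift beyond the usual scatter, a step that the limit leaves unreadable from compound 1 to compound 4. For compound 4 the estimated cytotoxicity in this assay is 60 ug/mL, within 30 ug/mL to 150 ug/mL, and most likely the assay again reports only a limit.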

Compound 4, half-maximal inhibitory concentration: > 50 ug/mL
Compound 4 gave a limit, no number; the forecaster's own chance of this, stated with the estimate: 80%; the middle value is on the limit's open side.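

In this assay, within the data shown here, compound 1 and compound 4 both give only a limit and no number, so no step from compound 1 to compound 4 can be read. The compounds shown leave open where the half-maximal inhibitory concentration of any of them lies: the limit of > 50 ug/mL in this assay, at which 3 of the 4 values shown sit.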